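Shortening the propylamino chain on the shared core

This account rests on a few compounds, and the source may have more. Where it says the series, first, only, none or still open, it means among the compounds named here.

Measured so far:
- compound 1 `CSc1nc(N)c2nc(O)n(Cc3ccccc3)c2n1`: 0.1 uM
- compound 2 `Nc1ncnc2c1nc(O)n2Cc1ccc(F)cc1`: 10 uM
- compound 3 `CCCNc1nc(N)c2nc(O)n(Cc3ccccc3)c2n1`: 0.1 uM

Compound 3 stands level with compound 1 on a functional assay (spleen, spleen) for activation, with Mus musculus as the target; a higher number here means that more compound is needed for the effect, a lower number that less compound is needed; the two of them share the lowest number of the three, and the step of no change at the digits printed from compound 1 to compound 3 (within the scatter) shows that exchanging methylsulfanyl for propylamino at that aromatic carbon left the reading unchanged. Compound 2, which carries a hydrogen at that position and a fluorine on the benzyl group, gives 10 uM, a far higher number than compound 3.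

Compound 4 `CNc1nc(N)c2nc(O)n(Cc3ccccc3)c2n1` is the next compound in this series. Relative to compound 3 the change is hydrogen in place of ethyl on a saturated chain carbon bound to a nitrogen on an aromatic ring; read one bond further out, propylamino becomes methylamino.

For the measured compounds named here, only one measured step touches this position, and it swapped one group for another of similar size rather than shortening a chain, so it is a weak guide. Compound 2 shows that removing the whole group, together with a second change, costs a great deal, but it does not tell what a shorter chain does. A modest rise in the number is therefore expected for compound 4, written as the step of a 3.0-fold higher number from compound 3 to compound 4 (0.48 log units; beyond the scatter), with the estimate 0.3 uM and a range from 0.1 uM to 3 uM.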

Compound 4, minimum effective concentration: 1 uM
For compound 4 the middle estimate is 3.3-fold (0.52 log units) below the measured one; the measured number falls inside the stated range.
By their numbers in this assay, from the lowest: compounds 1 and 3 (each within the scatter of the next); then compound 4; then compound 2.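

Cutting propylamino back to methylamino is the first change at this aromatic carbon that clearly moves the reading in this assay (a 10-fold higher number from compound 3 to compound 4 (1.00 log units; beyond the scatter)), so the length of the chain on this nitrogen matters here. The earlier swap of methylsulfanyl for propylamino (no change at the digits printed from compound 1 to compound 3 (within the scatter)) left the reading in place and could have suggested that this position tolerates any change, but methylamino in place of methylsulfanyl (a 10-fold higher number from compound 1 to compound 4 (1.00 log units; beyond the scatter)) shows that it does not. Across these three compounds, therefore, the methylsulfanyl and propylamino groups read alike, while the methylamino group needs more compound for the same effect, and no measurement here accounts for that shift.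

The compounds shown leave open whether the loss sets in gradually or abruptly, as ethylamino, the chain length between methylamino and propylamino, is not among them. They also leave open whether a butylamino group or a longer chain would hold the reading of propylamino, and how a plain amino group at this carbon would read on the same core.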